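Benzoxazole sulfonamides against mitochondrial malate dehydrogenase

A few compounds are considered here, and "the series" means these few. Any claim that something is new, unique, unknown or untested is made for them only; others in the source may bear on it.

Working notes on a small set of aryl sulfonamides carrying a benzoxazole, tested in an assay on isolated protein for inhibition of malate dehydrogenase, mitochondrial (Sus scrofa), with stated times of 45 min and 30 min; a lower number here means a stronger inhibitor, a higher number a weaker inhibitor. Compound 1 `O=S(=O)(Nc1ccc2oc(-c3ccccc3)nc2c1)c1cccc(C(F)(F)F)c1` gives only a limit in this assay, > 63000 nM. Compound 2 `Cc1ccc(S(=O)(=O)Nc2ccc(-c3nc4ccccc4o3)cc2)cc1` likewise gives only a limit in this assay, > 63000 nM. Where compound 2 stands is therefore not a number but the edge of the measurable range, and the same holds for the other value shown: the limit of > 63000 nM in this assay, at which 2 of the 2 values shown sit. Among the compounds with values here, no step between two measured compounds can be counted here, since neither value is a number.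

Compound 3 `O=S(=O)(Nc1ccc(-c2nc3ccccc3o2)cc1)c1cccs1` differs from compound 2 in one place: thiophen-2-yl in place of 4-methylphenyl on a sulfonyl sulfur. Within the data shown here, with both measured compounds sitting at the limit, there is no measured step on which to ground a direction for this change; the expectation is that compound 3 behaves like compound 2 and that the change from compound 2 to compound 3 brings no shift beyond the scatter, the expected step being a step that the limit leaves unreadable from compound 2 to compound 3. Compound 3 is estimated at 100000 nM in this assay, with a range from 40000 nM to 300000 nM, and most likely reported again as a limit.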

Compound 3, half-maximal inhibitory concentration: > 63000 nM
Compound 3: no number, only a limit; the forecaster's own chance of this, stated with the estimate: 85%; the middle value does not contradict the limit.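

Compound 3 gives only a limit in this assay, > 63000 nM, and no step can be read between compound 2 and compound 3. The compounds shown leave open whether thiophen-2-yl and 4-methylphenyl on a sulfonyl sulfur differ at all, and which change to this series would yield a measurable value: the limit of > 63000 nM in this assay, at which 3 of the 3 values shown sit.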